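A few compounds are considered here, and "the series" means these few. Any claim that something is new, unique, unknown or untested is made for them only; others in the source may bear on it.

Compound 1, `COCc1ncc2cnnc(S)n12`. In a functional assay for inhibition, with Homo sapiens as the target (a lower number here means a stronger inhibitor, a higher number a weaker inhibitor), compound 1 gives > 48000 nM, which is a limit of the assay and not a number.
Compound 2, `CCCc1ncc2cnnc(S)n12`. In this assay compound 2 gives > 48000 nM, again a limit of the assay.
Compound 3, `CCCc1ncc2cnnc(O)n12`. In this assay compound 3 gives > 48000 nM, also a limit of the assay.

Compound 2 therefore stands at a limit only, and the two further values shown are limits as well, so that the three measured compounds cannot be told apart: the limit of > 48000 nM in this assay, at which 3 of the 3 values shown sit. The step that the two limits leave unreadable from compound 1 to compound 2 and the step that the two limits leave unreadable from compound 2 to compound 3 are both left unreadable by the limits at either end, and neither of them touches the position that changes next.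

Compound 4, `CCCc1ncc2c(C)nnc(S)n12`, differs from compound 2 by methyl in place of hydrogen on an aromatic carbon. For the measured compounds named here, no measured step bears on this change, and the two steps that exist give no size and no direction. Going by the values given here, the only guide is that every value so far sits at the limit. Compound 4 is accordingly expected to give 60000 nM, with a range from 20000 nM to 200000 nM. The step that this estimate implies is expected to be a step that the limit leaves unreadable from compound 2 to compound 4, and the likeliest outcome is that compound 4 again ends at a limit rather than at a number.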

Compound 4, half-maximal inhibitory concentration: > 48000 nM
Compound 4 was reported as a limit; the forecaster's own chance of this, stated with the estimate: 85%; the middle value is on the limit's open side.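

In this assay compound 4 gives > 48000 nM as a limit of the assay and not a number. Compound 2 also stands at a limit, so no step between compound 2 and compound 4 can be read, and the compounds shown share one result: the limit of > 48000 nM in this assay, at which 4 of the 4 values shown sit. The compounds shown leave open whether any change to the shared core gives a measurable inhibitor.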